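This account rests on a few compounds, and the source may have more. Where it says the series, first, only, none or still open, it means among the compounds named here.

In a functional assay on HL-60 cells (Homo sapiens) for inhibition, read by MTT assay, with a stated time of 72 h; on this read-out lower numbers stand for stronger inhibition and higher numbers for weaker inhibition:
- compound 1 `Cc1nc(-c2ccccc2)c(C(=O)N2CCN(c3cccc(Cl)c3)CC2)o1`: 39.2 nM
- compound 2 `Cc1ccc(C)c(N2CCN(C(=O)c3oc(C)nc3-c3ccccc3)CC2)c1`: 31.3 nM

Going by the values given here, compound 1 holds the higher of only two numbers, but its value lies within the scatter of the value for compound 2. Compound 3 `COc1ccc(-c2nc(C)oc2C(=O)N2CCN(c3cccc(Cl)c3)CC2)cc1O` has 3-hydroxy-4-methoxyphenyl in place of phenyl on an aromatic carbon of the core: 3-hydroxy-4-methoxyphenyl in place of phenyl on an aromatic carbon. Among the compounds with values here, the only measured step, a 1.3-fold lower number from compound 1 to compound 2 (0.10 log units; within the scatter), changes the group on the amine nitrogen in a ring, so it says nothing directly about this place. With no measured guide to size or direction, no step beyond the scatter is expected in this assay, though the uncertainty is wide. The expected change is a 1.3-fold lower number from compound 1 to compound 3 (0.12 log units; within the scatter). The estimate for compound 3 is 30 nM, with an expected range of 6 nM to 150 nM.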

Compound 3, half-maximal inhibitory concentration: "not active" (no number reported)
The entry for compound 3 holds no number, and the estimate cannot be compared.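

Going by these compounds alone, compound 3 is reported as "not active" in this assay with no number, so no step from compound 1 to compound 3 can be read. The compounds shown leave open how large the change with 3-hydroxy-4-methoxyphenyl in place of phenyl is, and nothing shown accounts for this result.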